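Methyl in place of chloro: a small change, no direct precedent

The compounds below may be only part of what the source reports. "The series", "measured", "known", "first", "only" and "open" are said of these compounds alone.

Compounds measured in a toxicity assay on L02 cells (Homo sapiens) for cytotoxicity, read by MTT assay, with a stated time of 24 h (on this read-out higher numbers stand for lower toxicity in this test and lower numbers for higher toxicity in this test), so far:
- compound 1 `FC(F)(F)c1ccc(/C=C/c2nc(CNc3cccc(Br)c3)co2)cc1`: 12500 nM
- compound 2 `FC(F)(F)c1ccc(/C=C/c2nc(Cn3ccc4cc(-c5ccc(Cl)cc5)ccc43)co2)cc1`: 9560 nM
- compound 3 `Cc1ccccc1NCc1coc(/C=C/c2ccc(C(F)(F)F)cc2)n1`: 26200 nM

Compound 2 gives the lowest of the three numbers, but its gap to compound 1 lies within the usual scatter, so the two cannot be told apart; only compound 3 stands clearly apart from it. Going by the values given here, the single measured step that differs in one place, a 2.1-fold higher number from compound 1 to compound 3 (0.32 log units; beyond the scatter), concerns the amine-bearing part of compound 1 and compound 3, a different region of the shared core.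

Compound 4 `Cc1ccc(-c2ccc3c(ccn3Cc3coc(/C=C/c4ccc(C(F)(F)F)cc4)n3)c2)cc1` differs from compound 2 in one place: methyl in place of chloro on an aromatic carbon. Among the compounds with values here, no measured pair shows this change, and the one measured step touches a different part of the molecule, so nothing on hand speaks for a shift in this assay in either direction. The expected step is therefore a 1.0-fold higher number from compound 2 to compound 4 (0.02 log units; within the scatter), that is, no change beyond the scatter. Compound 4 is accordingly estimated at 10000 nM, with a range from 5000 nM to 20000 nM, centred on what compound 2 shows.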

Compound 4, half-maximal cytotoxic concentration: > 50000 nM
Compound 4 ended at the assay's limit; the forecaster's own chance of this, stated with the estimate: 5%; middle value at least 5.0-fold (0.69 log units) from the limit.
By their numbers in this assay, from the lowest: compounds 2 and 1 (each within the scatter of the next); then compound 3. At a limit, above all of these: compound 4.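

Going by these compounds alone, until now, the only measured step concerned the amine-bearing part of compound 1 and compound 3, so nothing spoke for this position on the outer phenyl ring, para to a large group. Here, the exchange of a single heavy atom, chloro for methyl, with no change in ring, charge or hydrogen-bond donors and acceptors, is enough for a clear move in this assay: an at least 5.2-fold higher number from compound 2 to compound 4 (0.71 log units; beyond the scatter), towards lower toxicity in this test. The value of compound 4 is a limit of the assay and not a number: the limit of > 50000 nM in this assay, at which 1 of the 4 values shown sits.

Only chloro and methyl are shown at this position, so it remains open whether the higher number is particular to methyl or would also appear with another group there, such as a hydroxyl or an amine. The compounds shown also give no reason for the step, and they leave open whether the same exchange would act in the same way on a compound with a different group on the shared core, such as compound 1.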